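Shifting the methyl on the ester aryl: cytotoxicity outlook

The compounds below may be only part of what the source reports. "The series", "measured", "known", "first", "only" and "open" are said of these compounds alone.

Compound 1 `Cc1cccc(C(=O)OC2CCC(CN3CCN(c4cc(=O)c5cc(C(F)(F)F)cc([N+](=O)[O-])c5s4)CC3)CC2)c1`: in an ADME assay on Vero cells (Chlorocebus sabaeus) for cytotoxicity, read by MTT assay, with a stated time of 48 h (a higher number here means a weaker inhibitor, a lower number a stronger inhibitor), compound 1 gives > 64 ug/mL, a limit of the assay.
Compound 2 `CS(=O)(=O)OC1CCC(CN2CCN(c3cc(=O)c4cc(C(F)(F)F)cc([N+](=O)[O-])c4s3)CC2)CC1`: compound 2 gives > 64 ug/mL, again a limit.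
Compound 3 `O=C(OC1CCC(CN2CCN(c3cc(=O)c4cc(C(F)(F)F)cc([N+](=O)[O-])c4s3)CC2)CC1)c1cccc(C(F)(F)F)c1`: compound 3 gives > 64 ug/mL, again a limit.

Compound 1 therefore stands only at the limit of this assay, with no number behind it. Compound 4 `Cc1ccc(C(=O)OC2CCC(CN3CCN(c4cc(=O)c5cc(C(F)(F)F)cc([N+](=O)[O-])c5s4)CC3)CC2)cc1` differs from it in one place: 4-methylphenyl in place of 3-methylphenyl on a carbonyl carbon. For the measured compounds named here, none of the measured steps can be read: a step that the two limits leave unreadable from compound 1 to compound 2, a step that the two limits leave unreadable from compound 1 to compound 3 and a step that the two limits leave unreadable from compound 2 to compound 3 all fall between two limits. Because of the limit of > 64 ug/mL in this assay, at which 3 of the 3 values shown sit, no change beyond the scatter is readable, and none is expected for this change either; the expected step that the limit leaves unreadable from compound 1 to compound 4 is small. Compound 4 is estimated at 80 ug/mL, expected between 40 ug/mL and 200 ug/mL, most likely again only a limit.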

Compound 4, half-maximal inhibitory concentration: > 64 ug/mL
Compound 4: no number, only a limit; the forecaster's own chance of this, stated with the estimate: 85%; the middle value is on the limit's open side.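

In this assay, the steps from compound 4 to compound 1, compound 2 and compound 3 cannot be read: the limit of > 64 ug/mL in this assay, at which 4 of the 4 values shown sit.

Going by these compounds, whether 4-methylphenyl in place of 3-methylphenyl changes anything in this assay, and how these four compounds rank there, stays open.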